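A few compounds are considered here, and "the series" means these few. Any claim that something is new, unique, unknown or untested is made for them only; others in the source may bear on it.

Going by the values given here, in a functional assay on SK-MEL-28 cells (Homo sapiens) for cytotoxicity, read by CCK-8 assay, with a stated time of 24 h (on this read-out higher numbers stand for weaker inhibition and lower numbers for stronger inhibition), compound 1 (`COc1ccccc1Oc1c(N)nc(-c2cccc(C)c2)nc1Cl`) gives 54000 nM and compound 2 (`COc1ccccc1Oc1c(N)nc(-c2ccc(F)cc2)nc1Cl`) gives 31900 nM, so compound 2 stands level with its only measured neighbour. Compound 3 (`COc1ccccc1Oc1c(N)nc(-c2ccc(F)cc2)nc1OCCO`) carries 2-hydroxyethoxy in place of chloro on an aromatic carbon. Among the compounds with values here, the only measured step, a 1.7-fold lower number from compound 1 to compound 2 (0.23 log units; within the scatter), concerns a different group, 4-fluorophenyl in place of 3-methylphenyl, and sets no size for this change. No step beyond the scatter is therefore expected in this assay, and no direction is favoured, so the range stays wide. The expected step is a 1.1-fold higher number from compound 2 to compound 3 (0.04 log units; within the scatter). The estimate for compound 3 is 35000 nM, with an expected range of 11000 nM to 100000 nM.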

Compound 3, half-maximal inhibitory concentration: 20100 nM
The estimate for compound 3 lay 1.7-fold (0.24 log units) above the measured number; measured number inside the range.
By their numbers in this assay, from the lowest: compounds 3, 2 and 1 (each within the scatter of the next, the first and the last beyond it).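

In this assay, the position next to the ring nitrogen accepts 2-hydroxyethoxy in place of chloro without a step beyond the scatter (a 1.6-fold lower number from compound 2 to compound 3 (0.20 log units; within the scatter)). The larger group brings a hydrogen-bond donor and hydrogen-bond acceptors that chloro lacks, yet this exchange does not separate compound 3 from compound 2. No measurement at hand accounts for this result.

From the compounds shown here alone, whether a methoxy group, a longer chain, an amine or a carboxylic acid at this position would give a step beyond the scatter remains open. Also open, going by these compounds, is whether 2-hydroxyethoxy behaves alike with 3-methylphenyl in place of 4-fluorophenyl.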